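The source may report more compounds than this note shows. Statements on the series, on what has been measured and on what is new or still open speak of the compounds shown alone.

Values measured in a functional assay on MCF7 cells (Homo sapiens) for antiproliferative activity, read by MTT assay, with a stated time of 72 h; a higher number here means a weaker inhibitor, a lower number a stronger inhibitor
compound 1 `COc1ncc(-c2ccc3c(c2)N(c2ccc(C)cc2)C(=O)CO3)cc1NS(=O)(=O)c1ccc(F)cc1` gives 15400 nM
compound 2 `COc1ncc(-c2ccc3c(c2)NC(=O)CO3)cc1NS(=O)(=O)c1ccc(F)cc1` gives 32300 nM
compound 3 `COc1ncc(-c2ccc3c(c2)N(C2CCCCC2)C(=O)CO3)cc1NS(=O)(=O)c1ccc(F)cc1` gives 30100 nM

Compound 3, at 30100 nM in this assay, lies within the scatter of both other compounds, although those two are separated by a modest step beyond it (a 2.1-fold higher number from compound 1 to compound 2 (0.32 log units; beyond the scatter)). The structural change phenyl in place of cyclohexyl on an amide-type nitrogen in a ring leads to compound 4 `COc1ncc(-c2ccc3c(c2)N(c2ccccc2)C(=O)CO3)cc1NS(=O)(=O)c1ccc(F)cc1` and puts phenyl in place of cyclohexyl on an amide-type nitrogen in a ring. The closest evidence is the step with cyclohexyl in place of 4-methylphenyl (a 2.0-fold higher number from compound 1 to compound 3 (0.29 log units; within the scatter)), which stays within the scatter. The step with cyclohexyl in place of hydrogen (a 1.1-fold lower number from compound 2 to compound 3 (0.03 log units; within the scatter)) is also within it. Only compound 1, at 15400 nM, has an aromatic ring at this place, so a small move toward its value is expected. The estimated step is a 1.5-fold lower number from compound 3 to compound 4 (0.18 log units; within the scatter) and so no clear shift beyond the scatter is expected. In this assay compound 4 is expected at 20000 nM within a range of 11000 nM to 36000 nM as estimated here.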

Compound 4, half-maximal inhibitory concentration: 8870 nM
Compound 4: middle estimate off by 2.3-fold (0.35 log units), on the high side; the whole stated range lies above it.
By their numbers in this assay, from the lowest: compounds 4, 1, 3 and 2 (each within the scatter of the next, the first and the last beyond it).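

In this assay, phenyl on the amide-type nitrogen separates clearly from both cyclohexyl (a 3.4-fold lower number from compound 3 to compound 4 (0.53 log units; beyond the scatter)) and hydrogen (a 3.6-fold lower number from compound 2 to compound 4 (0.56 log units; beyond the scatter)), although cyclohexyl and hydrogen could not be told apart at this place. The methyl of the 4-methylphenyl group makes no readable difference (a 1.7-fold lower number from compound 1 to compound 4 (0.24 log units; within the scatter)), so compound 1 and compound 4 point to an aromatic ring here as the better substituent, with the caveat that compound 1 itself stays within the scatter of compound 3. Nothing measured here explains why the aromatic ring makes this difference.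

The compounds shown leave open whether a benzyl group or a pyridine ring on this nitrogen would match phenyl. On these data alone, whether methoxy or chlorine on the phenyl ring would move the number beyond the scatter also remains open.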